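Hydroxy to methoxy change on compound 1: expected outcome

This account rests on a few compounds, and the source may have more. Where it says the series, first, only, none or still open, it means among the compounds named here.

Measured so far in a functional assay on NCI/ADR-RES cells (Homo sapiens) for inhibition, read by sulforhodamine B assay, with a stated time of 48 h; on this read-out lower numbers stand for stronger inhibition of growth and higher numbers for weaker inhibition of growth:
- compound 1 `CCOC(=O)C1=C(C)NC(=S)NC1c1ccc(O)c(O)c1` gives 24.3 ug/mL.
- compound 2 `CCOC(=O)C1=C(C)NC(=O)NC1C1CCCCC1` is reported only as a limit, > 250 ug/mL.
- compound 3 `CCCc1ccc(C2NC(=O)NC(C)=C2C(=O)OCC)cc1` gives 20.9 ug/mL.

Compound 1 carries the higher of the two numbers obtained, but compound 3 sits within the scatter of it, so no order between the two can be claimed. One of the three results is the limit of > 250 ug/mL in this assay, at which 1 of the 3 values shown sits, and that belongs to compound 2 alone.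

Compound 4 `CCOC(=O)C1=C(C)NC(=S)NC1c1ccc(O)c(OC)c1` is the next entry; it differs from compound 1 by methyl in place of hydrogen on an oxygen on an aromatic ring. For the measured compounds named here, no pair of measured compounds differs in a single place, so there is no measured step on which to lean. The expectation for this assay is a small step, most likely none beyond the scatter, with a slight lean toward a higher number. Compound 4 is thus estimated at 30 ug/mL, with a range from 12 ug/mL to 80 ug/mL. The expected step of a 1.2-fold higher number from compound 1 to compound 4 (0.09 log units; within the scatter) is modest.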

Compound 4, concentration for 50% growth inhibition: 59.7 ug/mL
Compound 4: middle estimate off by 2.0-fold (0.30 log units), on the low side, and the stated range covers the measured number.
By their numbers in this assay, from the lowest: compounds 3 and 1 (each within the scatter of the next); then compound 4. At a limit, above all of these: compound 2.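

In this assay, the change of hydroxy to methoxy gives a 2.5-fold higher number from compound 1 to compound 4 (0.39 log units; beyond the scatter), so this position does not tolerate the added methyl without a measurable shift. For the compounds shown here, this is the first comparison that differs in one place only, and it gives the free hydroxy on this aromatic ring a measured link to growth inhibition, which the unconnected values of the earlier compounds could not provide. Nothing available bears on the reason for this step.

Going by these compounds, a single step at one position sets no trend, and whether the second hydroxy of compound 1 responds in the same way remains open. Also unresolved is how a longer chain such as ethoxy on this oxygen, or an amine in place of the hydroxy, would compare.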